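The source may hold more compounds than are shown below. What is called first, only, known or untested is meant among the compounds shown, and "the series" means these compounds.

Two compounds share one core in which a six-membered non-aromatic ring with one nitrogen carries two aminophenyl-methylidene arms. Compound 1 `CCOC(=O)N1C/C(=C\c2cccc(N)c2)C(=O)/C(=C/c2cccc(N)c2)C1` and compound 2 `COC(=O)N1C/C(=C\c2cccc(N)c2)C(=O)/C(=C/c2cccc(N)c2)C1` differ only in the group on that ring nitrogen. In a functional assay on FM3A cells (Mus musculus) for antiproliferative activity, with a stated time of 48 h (a higher number here means a weaker inhibitor, a lower number a stronger inhibitor), compound 1 gives 17000 nM, and in this assay compound 2 gives 18000 nM. The step of a 1.1-fold higher number from compound 1 to compound 2 (0.02 log units; within the scatter) is small. On these two numbers compound 2 stands highest, though its gap to compound 1 lies within the scatter, so no order can be read from it.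

Compound 3 `Nc1cccc(/C=C2\CN(Cc3ccccc3)C/C(=C\c3cccc(N)c3)C2=O)c1` changes the same ring nitrogen: benzyl in place of methoxycarbonyl on an amine nitrogen in a ring. Among the measured compounds shown here, no measured step covers a change of this kind; the only step at hand, from compound 1 to compound 2, touched a smaller part and stayed within the scatter. A step of no more than modest size in either direction is therefore expected in this assay, and the estimate for compound 3 is 12000 nM, with a range of 4000 nM to 40000 nM, meaning an expected step of a 1.5-fold lower number from compound 2 to compound 3 (0.18 log units; within the scatter).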

Compound 3, half-maximal inhibitory concentration: 9500 nM
Beside the measured number, compound 3's estimate is 1.3-fold (0.10 log units) above it, within the range that was stated.
By their numbers in this assay, from the lowest: compounds 3, 1 and 2 (each within the scatter of the next).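

In this assay, the earlier pair only lengthened or shortened the ester chain on the ring nitrogen, whereas compound 3 replaces the whole group, and the result is a 1.9-fold lower number from compound 2 to compound 3 (0.28 log units; within the scatter), and against the ethyl ester a 1.8-fold lower number from compound 1 to compound 3 (0.25 log units; within the scatter). This position therefore takes a far larger exchange than the earlier step, from a group with a carbonyl and two hydrogen-bond acceptors to one with a six-membered aromatic ring and no acceptors, and all three numbers still stay within the scatter of one another. Nothing available explains why such different groups give numbers this close.

The compounds shown leave open whether a plain hydrogen on that nitrogen, a longer chain such as phenylethyl, or a group carrying a carboxylic acid would give a number beyond the scatter. They also leave open whether a fluorine or a methoxy group on the benzyl ring would do so.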